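Cyano in Place of Chloro at Compound 4

A few compounds are considered here, and "the series" means these few. Any claim that something is new, unique, unknown or untested is made for them only; others in the source may bear on it.

In a functional assay on MDA-MB-231 cells (Homo sapiens) for inhibition, read by MTT assay, with a stated time of 5 days (a lower number here means a stronger inhibitor, a higher number a weaker inhibitor), compound 1 (`Cc1cc(Nc2nc(NCc3ccccc3Cl)nc3[nH]ncc23)n[nH]1`) gives 4210 nM, compound 2 (`Cc1cc(Nc2nc(NCc3ccccc3Br)nc3[nH]ncc23)n[nH]1`) gives 3990 nM and compound 3 (`Cc1cc(Nc2nc(NCc3ccc(Cl)cc3)nc3[nH]ncc23)n[nH]1`) gives 7500 nM. Compound 3 therefore lies within the scatter of both of the others. Compound 4 (`Cc1cc(Nc2nc(NCc3ccc(C#N)cc3)nc3[nH]ncc23)n[nH]1`) differs from compound 3 in one place: cyano in place of chloro on an aromatic carbon. This puts cyano in place of chloro on an aromatic carbon.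

Among the compounds with values here, no measured step makes this exchange, so the evidence is indirect. Bromo in place of chloro gave a 1.1-fold lower number from compound 1 to compound 2 (0.02 log units; within the scatter). 4-chlorophenyl in place of 2-chlorophenyl gave a 1.8-fold higher number from compound 1 to compound 3 (0.25 log units; within the scatter), and 4-chlorophenyl in place of 2-bromophenyl gave a 1.9-fold higher number from compound 2 to compound 3 (0.27 log units; within the scatter). All three steps stay within the scatter, but none involves cyano, so the expectation remains loose. No step beyond the scatter is expected in this assay, in either direction. The estimated change is a 1.2-fold lower number from compound 3 to compound 4 (0.06 log units; within the scatter). For compound 4 the expected value is 6500 nM, with an estimated range from 2800 nM to 15000 nM.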

Compound 4, half-maximal inhibitory concentration: 1360 nM
Beside the measured number, compound 4's estimate is 4.8-fold (0.68 log units) above it, outside the stated range (below it).
By their numbers in this assay, from the lowest: compound 4; then compounds 2, 1 and 3 (each within the scatter of the next).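

In this assay chloro to cyano on this aromatic carbon gives a 5.5-fold lower number from compound 3 to compound 4 (0.74 log units; beyond the scatter) and so is a step beyond the scatter, whereas every earlier step stayed within it; the group on this carbon therefore does matter in this assay. The 4-cyanophenyl group also separates from both halogen-bearing rings with the substituent elsewhere, with a 2.9-fold lower number from compound 2 to compound 4 (0.47 log units; beyond the scatter) and with a 3.1-fold lower number from compound 1 to compound 4 (0.49 log units; beyond the scatter) on the same saturated chain carbon. No measurement here bears on why cyano and chloro differ at this position.

On these data alone, what a carboxylic acid, an amide or a methoxy group would do in place of cyano stays open. So does whether cyano would give a like step at the ring position that holds the halogen in compound 1 and compound 2.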